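Weak HSP60 inhibitors: swapping a fluorine for a hydroxyl

This account rests on a few compounds, and the source may have more. Where it says the series, first, only, none or still open, it means among the compounds named here.

Compound 1 `O=S(=O)(Nc1ccc(-c2nc3ccccc3o2)cc1)c1cccc(F)c1` gives 71000 nM in an assay on cells for inhibition of HSP60/HSP10 (Homo sapiens), with a stated time of 60 min (on this read-out higher numbers stand for weaker inhibition and lower numbers for stronger inhibition), the higher of the two numbers seen so far. Compound 2 `CS(=O)(=O)Nc1ccc(-c2nc3cc(NS(=O)(=O)c4ccc(Cl)s4)ccc3o2)cc1` gives 43000 nM in the same assay; the two values lie within the scatter of each other, so neither can be called the weaker. Compound 3 `O=S(=O)(Nc1ccc(-c2nc3ccccc3o2)cc1)c1ccccc1O` differs from compound 1 in one place: 2-hydroxyphenyl in place of 3-fluorophenyl on a sulfonyl sulfur. For the measured compounds named here, no step between measured compounds guides this change, so the step from compound 1 to compound 3 is expected to be small, a 1.2-fold lower number from compound 1 to compound 3 (0.07 log units; within the scatter), in no direction beyond the scatter. Compound 3 is therefore estimated at 60000 nM, within 20000 nM to 180000 nM.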

Compound 3, half-maximal inhibitory concentration: > 100000 nM
Compound 3 was reported as a limit; the forecaster's own chance of this, stated with the estimate: 20%; middle value at least 1.6-fold (0.22 log units) from the limit.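

On a sulfonyl sulfur, 2-hydroxyphenyl in place of 3-fluorophenyl gives an at least 1.4-fold higher number from compound 1 to compound 3 (0.14 log units; that floor lies within the scatter), so this change brought no stronger inhibition in this assay. Compound 3 stands at a limit of the assay, so the true size of this step stays unknown: the limit of > 100000 nM in this assay, at which 1 of the 3 values shown sits.

The compounds shown leave open whether the hydroxyl or its place on the ring governs this reading, since the single change alters both. They also leave open whether an amine or a carboxylic acid on that phenyl ring would give a lower number.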